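The compounds below may be only part of what the source reports. "The series", "measured", "known", "first", "only" and "open" are said of these compounds alone.

Two related compounds have been tested so far, and both sit at the upper edge of what the test can report. Compound 1 `C[C@@H]1C[C@H]2C(=O)C(C)(C)[C@H](OC=O)CC[C@]2(O)[C@@]1(C)CCC1=CC(=O)OC1` was measured in a functional assay on HepG2 cells (Homo sapiens) for cytotoxicity, read by MTT assay, with a stated time of 3 days; on this read-out higher numbers stand for weaker inhibition and lower numbers for stronger inhibition. In this assay compound 1 gives only a limit, > 10000 nM. Compound 2 `C[C@@H]1CC[C@@]2(O)[C@@H](C[C@@H](O)C2(C)C)C(=O)[C@@]1(C)CCC1=CC(=O)OC1` shares most of its framework with compound 1 and was measured in the same way. In this assay compound 2 likewise gives only a limit, > 10000 nM. Where compound 2 stands is therefore not a number but a boundary, and it is not alone there: the limit of > 10000 nM in this assay, at which 2 of the 2 values shown sit. Going by the values given here, no comparison between two measured compounds differing in a single place is available, so no measured step can be pointed to.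

Compound 3 `C[C@@H]1CC[C@]2(O)[C@H](C[C@@H](O)C2(C)C)C(=O)[C@@]1(C)CCC1=CC(=O)OC1` is the next compound and has not yet been measured in this assay. It differs from compound 2 as follows: the two compounds have the same atoms and bonds and differ only in configuration as drawn: 2 of 5 stereo elements differ; a stereocentre at a saturated ring carbon is drawn R in compound 2 and S in compound 3; a stereocentre at a saturated ring carbon is drawn R in compound 2 and S in compound 3. The two compounds therefore have exactly the same atoms and bonds.

Given that compound 2 sits at the limit, the expectation is that the step that the limit leaves unreadable from compound 2 to compound 3 stays within the usual scatter, with no clear direction. Compound 3 is accordingly estimated at 15000 nM, within a range from 5000 nM to 50000 nM, most likely reported again as a limit.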

Compound 3, half-maximal inhibitory concentration: > 10000 nM
Compound 3 was reported as a limit (the forecaster's own chance of this, stated with the estimate: 85%); the middle value lies beyond the limit too.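

In this assay compound 3 gives > 10000 nM, which is a limit and not a number. Going by these compounds alone, compound 2 also stands at a limit, so no step from compound 2 to compound 3 can be read. Still open is whether the change in configuration alters cytotoxicity at all, and what real number any of these compounds would give: the limit of > 10000 nM in this assay, at which 3 of the 3 values shown sit.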